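The compounds below may be only part of what the source reports. "The series", "measured", "known", "first", "only" and "open" are said of these compounds alone.

Compound 1 `COc1ccc(-c2c(S(=O)(=O)c3cccc(C#N)c3)cnc3cc(F)ccc23)cc1` — 0.92 mL/min
Compound 2 `O=S(=O)(c1ccc(F)c(Cl)c1)c1cnc2cc(F)ccc2c1-c1ccc(Cl)cc1` — 0.39 mL/min
Compound 3 `COc1ccc(-c2c(S(=O)(=O)c3cccc(F)c3)cnc3cc(F)ccc23)cc1` — 1.89 mL/min

In an ADME assay on microsomes from liver (Homo sapiens) for metabolic stability, tested at 2.5 uM (a lower number here means slower removal, a higher number faster removal of the compound), compound 1 gives 0.92 mL/min, the second highest of the three numbers. Its nearest neighbour is compound 3, whose value is higher, and the furthest is compound 2, whose value is lower. Within the data shown here, the only step measured between compounds that differ in one place is a 2.1-fold higher number from compound 1 to compound 3 (0.31 log units; beyond the scatter).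

Compound 4 `N#Cc1cccc(S(=O)(=O)c2cnc3cc(F)ccc3c2-c2cccc(Cl)c2)c1` differs from compound 1 in one place: 3-chlorophenyl in place of 4-methoxyphenyl on an aromatic carbon. Among the measured compounds shown here, no measured step bears directly on this change; the step from compound 1 to compound 3 concerns a different position and says nothing about it. Compound 2 also carries a chlorophenyl group and shows a lower number than compound 1, but it differs in a second place too, so it is only a loose hint.

On this basis the account expects a step from compound 1 to compound 4 of a 1.4-fold lower number from compound 1 to compound 4 (0.15 log units; within the scatter), that is a slightly lower number or none beyond the scatter. Compound 4 is therefore estimated at 0.65 mL/min, with a range from 0.3 mL/min to 1.4 mL/min.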

Compound 4, intrinsic clearance in a liver preparation (reported as CLH), per the amount of preparation that the assay uses: 0.99 mL/min
The estimate for compound 4 lay 1.5-fold (0.18 log units) below the measured number, and the stated range covers the measured number.
By their numbers in this assay, from the lowest: compound 2; then compounds 1, 4 and 3 (each within the scatter of the next, the first and the last beyond it).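

In this assay, 3-chlorophenyl in place of 4-methoxyphenyl on this aromatic carbon of the shared core gives a 1.1-fold higher number from compound 1 to compound 4 (0.03 log units; within the scatter). This position therefore tolerates the exchange of one substituted phenyl for another, including the loss of the methoxy group, with no change in the number beyond the scatter. Nothing available explains why the number holds across this change.

The step alters both the substituent and its place on the phenyl ring, so the compounds shown do not separate the two, and a 3-methoxyphenyl or an unsubstituted phenyl at this carbon would be needed to do so. They also leave open whether a group of another kind here, such as an amine or a carboxylic acid, would stay within the scatter, and whether fluoro in place of cyano would give a similar step with 3-chlorophenyl present.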